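Replacing a flexible linker with an aromatic one in a dual-action hydroxamate

The source may report more compounds than this note shows. Statements on the series, on what has been measured and on what is new or still open speak of the compounds shown alone.

Of the compounds shown here, two sharing one core have been measured so far. Compound 1, `CCOc1cc(C(C)(C)C)ccc1C1=NC(c2ccc(Cl)cc2)C(c2ccc(Cl)cc2)N1C(=O)N1CCN(CCCCCC(=O)NO)CC1`, carries a 5-(hydroxycarbamoyl)pentyl chain on the amine nitrogen of its six-membered non-aromatic ring, and in a functional assay on HCT-116 cells (Homo sapiens) for antiproliferative activity, read by CCK-8 assay, with a stated time of 72 h (on this read-out lower numbers stand for stronger inhibition and higher numbers for weaker inhibition), compound 1 gives 4030 nM. Compound 2, `CCOc1cc(C(C)(C)C)ccc1C1=NC(c2ccc(Cl)cc2)C(c2ccc(Cl)cc2)N1C(=O)NCCCCCCC(=O)Nc1ccccc1N`, bears a different tail, and in this assay compound 2 gives 10100 nM. Of the two numbers, compound 1 has the lower one, and the gap to compound 2 lies beyond the usual scatter.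

The compound still to be measured is compound 3, `CCOc1cc(C(C)(C)C)ccc1C1=NC(c2ccc(Cl)cc2)C(c2ccc(Cl)cc2)N1C(=O)N1CCN(c2ncc(C(=O)NO)cn2)CC1`. The change from compound 1 to compound 3 is 5-(hydroxycarbamoyl)pyrimidin-2-yl in place of 5-(hydroxycarbamoyl)pentyl on an amine nitrogen in a ring. Among the measured compounds shown here, no measured pair in this set isolates such a change, so its effect cannot be read from the data; the only anchor is the value of compound 1. Given that, the step for compound 3 is expected to be modest, and the number for compound 3 is estimated at 2500 nM, within a range from 800 nM to 8000 nM, which would mean a step of a 1.6-fold lower number from compound 1 to compound 3 (0.21 log units; within the scatter).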

Compound 3, half-maximal inhibitory concentration: 980 nM
Compound 3: middle estimate off by 2.6-fold (0.41 log units), on the high side, and the stated range covers the measured number.
By their numbers in this assay, from the lowest: compound 3; then compound 1; then compound 2.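

At the amine nitrogen of the six-membered non-aromatic ring, the hydroxamate-bearing tail does not have to be an open chain: in this assay, 5-(hydroxycarbamoyl)pyrimidin-2-yl in place of 5-(hydroxycarbamoyl)pentyl gives a 4.1-fold lower number from compound 1 to compound 3 (0.61 log units; beyond the scatter). The earlier compounds shown here differed in more than one place in their tails, whereas this pair isolates a single change at this position and shows that a tail with one six-membered aromatic ring holding two hetero atoms can lower the number beyond the usual scatter. Nothing measured here bears on why the number moves.

The change alters several things at once, since a ring enters, the chain leaves, and the counts of nitrogen atoms and hydrogen-bond acceptors rise, and the compounds shown do not separate these features. As far as these compounds go, it remains open whether a phenyl ring carrying the same hydroxycarbamoyl group would match the pyrimidine, and whether a longer chain such as 7-(hydroxycarbamoyl)heptyl would shift the number from that of the pentyl compound.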